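The source may report more compounds than this note shows. Statements on the series, on what has been measured and on what is new or still open speak of the compounds shown alone.

Compound 1 `COc1ccc(/C=C/C(=O)/C=C/c2ccc(OCc3cn(CCOc4cc(=O)oc5ccccc45)nn3)c(OC)c2)cc1OC`: 19%
Compound 2 `COc1cc(/C=C/C(=O)/C=C/c2cccc3ccccc23)ccc1OCc1cn(CCCOc2cc(=O)oc3ccccc23)nn1`: 8%
Compound 3 `COc1cc(/C=C/C(=O)/C=C/c2ccccc2)ccc1OCc1cn(CCCCOc2cc(=O)oc3ccccc23)nn1`: "not active" (no number reported)

All three were tested in a functional assay on PC-3 cells (Homo sapiens) for inhibition, read by sulforhodamine B assay, with a stated time of 48 h, tested at 50 uM; a higher number here means more inhibition of growth at the concentration tested, a lower number less inhibition of growth. Compound 1 stands highest of the two reported numbers; compound 2 comes out lower by a gap beyond the usual scatter, and compound 3 is recorded as not active, with no number given. Going by the values given here, no two measured compounds differ in just one place, so no single step can be read off directly.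

Compound 4 `COc1cc(/C=C/C(=O)/C=C/c2cccs2)ccc1OCc1cn(CCOc2cc(=O)oc3ccccc23)nn1` has not yet been measured. It differs from compound 1 in one place: thiophen-2-yl in place of 3,4-dimethoxyphenyl on a double-bonded chain carbon bound to a double-bonded chain carbon. The other two measured compounds carry other rings at this same place, together with other chains, and both came out low. On that basis the change is expected to bring a fall, estimated as a step of a number 9 percentage points lower from compound 1 to compound 4 (within the scatter), small enough that it may still sit inside the usual scatter. Compound 4 is therefore expected to give about 10%, with an estimated range from 0% to 22%.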

Compound 4, percent growth inhibition at one concentration: 12%
For compound 4 the middle estimate is 2 percentage points below the measured one, and the stated range covers the measured number.
By their numbers in this assay, from the lowest: compounds 2, 4 and 1 (each within the scatter of the next, the first and the last beyond it).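

In this assay, the exchange of 3,4-dimethoxyphenyl for thiophen-2-yl on a double-bonded chain carbon bound to a double-bonded chain carbon reads as a number 7 percentage points lower from compound 1 to compound 4 (within the scatter). Going by these compounds alone, this is the first direct one-place comparison at this position, and it shows that a six-membered carbon ring with 10 heavy atoms and a five-membered ring with 5 heavy atoms, one of them sulfur, cannot be told apart here at the single concentration tested. Nothing available explains this result or says what the ring contributes.

Within the data shown here, compounds 2 and 3 differ from these two in more than one place, so no steps to them can be read. Also open, on these data alone, is whether a phenyl ring carrying an amine or a carboxylic acid at this place would give a step beyond the scatter.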